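Methyl in Place of Formyl: Expected Growth Inhibition of Compound 3

The source may report more compounds than this note shows. Statements on the series, on what has been measured and on what is new or still open speak of the compounds shown alone.

compound 1 `CC1(C)CCC[C@]2(C)[C@@H](/C=C/C3=CCOC3=O)C(C=O)=CC(=O)[C@@H]12`: 38700 nM
compound 2 `CC(C)(O)C1CC[C@@]2(C)CCC[C@@](C)(O)[C@@H]2C1`: 73600 nM

Of the compounds shown here, two have so far been measured in a functional assay on SK-N-SH cells (Homo sapiens) for inhibition, read by sulforhodamine B assay; on this read-out higher numbers stand for weaker inhibition of growth and lower numbers for stronger inhibition of growth. Compound 1 gives 38700 nM, the lower of the two numbers, though its gap to compound 2 at 73600 nM lies within the scatter, so neither compound can be called the stronger inhibitor of growth. Among the compounds with values here, no step between compounds that differ in one place is available, and compound 2 shares only part of its structure with compound 1, so the two values say nothing about any single change.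

Compound 3 `CC1=CC(=O)[C@H]2C(C)(C)CCC[C@]2(C)[C@H]1/C=C/C1=CCOC1=O` is the next compound to be measured in this assay. It differs from compound 1 in one place: methyl in place of formyl on a double-bonded ring carbon. Within the data shown here, nothing among the measured compounds shows how a methyl in place of a formyl acts in this assay. Without such a guide, the expected step is a moderate one towards a higher number, that is towards weaker inhibition of growth, with a wide range around it: a 1.8-fold higher number from compound 1 to compound 3 (0.26 log units; within the scatter). In this assay compound 3 is therefore estimated at 70000 nM, between 25000 nM and 200000 nM.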

Compound 3, concentration for 50% growth inhibition: 8200 nM
For compound 3 the middle estimate is 8.5-fold (0.93 log units) above the measured one; measured number below the stated range.
By their numbers in this assay, from the lowest: compound 3; then compounds 1 and 2 (each within the scatter of the next).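

In this assay, within the data shown here, the replacement of formyl by methyl on this double-bonded ring carbon gives the first step that can be read between compounds differing in one place: a 4.7-fold lower number from compound 1 to compound 3 (0.67 log units; beyond the scatter), a change beyond the scatter towards stronger inhibition of growth. The formyl is thus not required at this position for growth inhibition on the shared core, and the methyl, with one heavy atom and no hydrogen-bond acceptor, goes with the lower number. No measurement at hand accounts for this step.

It remains open whether the lower number belongs to the methyl itself or simply follows from the loss of the formyl: the compounds shown carry no ethyl, hydroxymethyl or carboxylic acid on this ring carbon, and none with a hydrogen alone. Going by these compounds, it also remains open whether the same replacement would give a step of similar size if the group of 8 heavy atoms on the ring atom next to this carbon were exchanged for a shorter chain or an amine.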